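The compounds below may be only part of what the source reports. "The series", "measured", "known", "first", "only" and "open" are said of these compounds alone.

In a functional assay on HCT-116 cells (Homo sapiens) for cytotoxicity, read by MTT assay, with a stated time of 72 h (a lower number here means a stronger inhibitor, a higher number a weaker inhibitor), compound 1 `O=C(NCc1ccc(F)cc1)c1nc(NCCO)c2cccnc2c1O` stands with "not determined" (no result reported) as its entry. Compound 2 `O=C(NCc1ccc(F)cc1)c1nc(Br)c2cccnc2c1NCCCNc1c(C(=O)NCc2ccc(F)cc2)nc(Br)c2cccnc12` gives > 20000 nM as its reading, which is a limit and not a number. Compound 3 `NCCCNc1c(C(=O)NCc2ccc(F)cc2)nc(Br)c2cccnc12` gives > 20000 nM as its reading, again a limit and not a number. Among the compounds with values here, compound 3 therefore has no number of its own, and no step between measured compounds is available. Compound 4 `N[C@H]1CC[C@H](Nc2c(C(=O)NCc3ccc(F)cc3)nc(Br)c3cccnc23)CC1` differs from compound 3 in one place, where 4-aminocyclohexyl in place of 3-aminopropyl on a nitrogen on an aromatic ring applies, with 4-aminocyclohexyl in place of 3-aminopropyl on a nitrogen on an aromatic ring. Within the data shown here, with compound 3 resting on the limit of > 20000 nM in this assay, at which 2 of the 3 values shown sit, as the only guide, a modest step towards stronger inhibition is expected in this assay for this change, and the result could well be a limit again. The estimated move is an at least 1.3-fold lower number from compound 3 to compound 4 (0.12 log units; that floor lies within the scatter) and remains a rough expectation. For compound 4 the expected value is 15000 nM within an estimated range of 4000 nM to 40000 nM in this measurement.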

Compound 4, half-maximal inhibitory concentration: 7000 nM
The estimate for compound 4 lay 2.1-fold (0.33 log units) above the measured number; the range from low to high includes it.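

In this assay, compound 4 holds the only number among the compounds shown, and the change on this nitrogen gives an at least 2.8-fold lower number from compound 3 to compound 4 (0.45 log units; beyond the scatter). The earlier compounds shown here offered no measured step at this position; this one shows that 4-aminocyclohexyl in place of 3-aminopropyl moves the reading off the limit of the assay and beyond the usual scatter. Compound 3 has only a limit and not a number, so the step is a floor and its true size remains unknown: the limit of > 20000 nM in this assay, at which 2 of the 4 values shown sit.

The compounds shown leave open whether the six-membered ring itself matters or whether a longer chain, such as 5-aminopentyl, would serve equally well on this nitrogen. They also leave open how the other stereoisomer of 4-aminocyclohexyl would read, and whether a hydroxyl could stand in place of its amine.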